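A few compounds are considered here, and "the series" means these few. Any claim that something is new, unique, unknown or untested is made for them only; others in the source may bear on it.

Measured in an ADME assay on Vero cells (Chlorocebus sabaeus) for cytotoxicity, read by MTT assay, with a stated time of 48 h (on this read-out higher numbers stand for weaker inhibition and lower numbers for stronger inhibition), with all three values being limits:

Compound 1 `O=C(N/N=C/c1ccc(CO)cc1)c1ccncc1`: > 200000 nM
Compound 2 `CCCCCCCCCC(=O)NNC(=O)c1ccncc1`: > 75000 nM
Compound 3 `O=C(N/N=C/c1cccc(CO)c1)c1ccncc1`: > 200000 nM

Compound 1 gives > 200000 nM, which is a limit and not a number. It sits at the limit of > 200000 nM in this assay, at which 2 of the 3 values shown sit, so no exact figure is available for it. Compound 4 `O=Cc1ccc(/C=N/NC(=O)c2ccncc2)cc1` keeps the core of compound 1 and changes one group: formyl in place of hydroxymethyl on an aromatic carbon, para to a large group (formyl in place of hydroxymethyl on an aromatic carbon). For the measured compounds named here, no measured pair here shows what such a change does. The expected change, an at least 1.1-fold lower number from compound 1 to compound 4 (0.04 log units; that floor lies within the scatter), is small and, if anything, toward stronger inhibition. For compound 4 the estimated value is 180000 nM, with an expected range from 60000 nM to 400000 nM.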

Compound 4, half-maximal inhibitory concentration in the Vero assay: > 200000 nM
Compound 4: a limit, no number (the forecaster's own chance of this, stated with the estimate: 65%); middle value at least 1.1-fold (0.04 log units) from the limit.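

In the Vero assay compound 1 gives > 200000 nM, which is a limit. In the Vero assay compound 4 gives > 200000 nM, which is also a limit. For the compounds shown here, no step between compound 1 and compound 4 can be read. Going by these compounds, whether formyl in place of hydroxymethyl changes the half-maximal inhibitory concentration at all stays open. In a physicochemical assay for lipophilicity, using the shake flask method, measured as octanol-water partition (a lower number here means a more polar compound, a higher number a more lipophilic compound), compound 1 gives 0.731 and compound 4 gives 1.32.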